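Cyclopropyl for 4-methylphenyl on the ring amide nitrogen

This account rests on a few compounds, and the source may have more. Where it says the series, first, only, none or still open, it means among the compounds named here.

In a functional assay on A549 cells (Homo sapiens) for antiproliferative activity, read by MTT assay, with a stated time of 72 h (a lower number here means a stronger inhibitor, a higher number a weaker inhibitor), compound 1 `COc1ncc(-c2ccc3c(c2)N(c2ccc(C)cc2)C(=O)CO3)cc1NS(=O)(=O)c1ccc(F)cc1` gives 5870 nM, within the scatter of compound 3 `CC(C)N1C(=O)COc2ccc(-c3cnc(Cl)c(NS(=O)(=O)c4ccc(F)cc4)c3)cc21` at 5100 nM. Compound 2 `COc1ccc(N2C(=O)COc3ccc(-c4cnc(Cl)c(NS(=O)(=O)c5ccc(F)cc5)c4)cc32)cc1` gives the highest number of the three at 30400 nM.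

Compound 4 `COc1ncc(-c2ccc3c(c2)N(C2CC2)C(=O)CO3)cc1NS(=O)(=O)c1ccc(F)cc1` keeps the core of compound 1 and carries cyclopropyl in place of 4-methylphenyl on an amide-type nitrogen in a ring.

For the measured compounds named here, the only measured step that bears on this is a 6.0-fold lower number from compound 2 to compound 3 (0.78 log units; beyond the scatter), with isopropyl in place of 4-methoxyphenyl on an amide-type nitrogen in a ring. Going by the values given here, that pair also differs from compound 1 elsewhere in the core, and no measured compound carries cyclopropyl, so the step transfers only in part. Compound 1 at 5870 nM already sits within the scatter of the isopropyl compound 3, which argues for a smaller gain.

A modest move to a lower number is therefore expected, an estimated 2.9-fold lower number from compound 1 to compound 4 (0.47 log units; beyond the scatter). Compound 4 is estimated at 2000 nM, with an expected range of 500 nM to 7000 nM.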

Compound 4, half-maximal inhibitory concentration: 3320 nM
Compound 4: the middle estimate sits 1.7-fold (0.22 log units) below what was measured; low and high end bracket the measured number.
By their numbers in this assay, from the lowest: compounds 4, 3 and 1 (each within the scatter of the next); then compound 2.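

On the core of compound 1, in this assay, cyclopropyl in place of 4-methylphenyl on the ring amide nitrogen gives a 1.8-fold lower number from compound 1 to compound 4 (0.25 log units; within the scatter), so this exchange of an aromatic ring for a much smaller carbon ring does not separate the pair. The step of a 6.0-fold lower number from compound 2 to compound 3 (0.78 log units; beyond the scatter), with isopropyl in place of 4-methoxyphenyl, therefore has no counterpart beyond the scatter in this pair, although the two pairs differ in their groups and elsewhere in the core. Nothing available explains the outcome at this position.

Open, going by these compounds, is whether a longer chain ending in an amine or a carboxylic acid on this nitrogen would give a step beyond the scatter. Also open, on these data alone, is what the methoxy and chloro groups that separate compounds 1 and 4 from compounds 2 and 3 contribute on their own.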